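The source may report more compounds than this note shows. Statements on the series, on what has been measured and on what is new or still open speak of the compounds shown alone.

Measured so far in a functional assay on MCF7 cells (Homo sapiens) for cytotoxicity, read by MTT assay, with a stated time of 96 h (on this read-out higher numbers stand for weaker inhibition and lower numbers for stronger inhibition), are these compounds:
- compound 1 `COc1cc(C(=O)c2cn(-c3ccccc3)cc2-c2ccc(Cl)cc2)cc(OC)c1OC` with 290 nM
- compound 2 `COc1cc(C(=O)c2cn(-c3ccccc3)cc2-c2ccccc2Br)cc(OC)c1OC` with 190 nM
- compound 3 `COc1ccccc1-c1cn(-c2ccccc2)cc1C(=O)c1cc(OC)c(OC)c(OC)c1` with 190 nM

Compound 3 shares its number with compound 2, and compound 1 stays within the scatter of both. Within the data shown here, compound 4 `COc1cccc(-c2cn(-c3ccccc3)cc2C(=O)c2cc(OC)c(OC)c(OC)c2)c1` has the same atoms joined differently, with 3-methoxyphenyl in place of 2-methoxyphenyl on an aromatic carbon as the only change. Among the measured compounds shown here, no measured compound carries 3-methoxyphenyl, so this exact change is untested. The closest guides are swaps of that aromatic group, which gave a 1.5-fold lower number from compound 1 to compound 2 (0.18 log units; within the scatter) and a 1.5-fold lower number from compound 1 to compound 3 (0.18 log units; within the scatter) and no change at the digits printed from compound 2 to compound 3 (within the scatter) in turn. With these small steps as a guide, no step beyond the scatter is expected in this assay for this change. The expected size is a 1.1-fold higher number from compound 3 to compound 4 (0.02 log units; within the scatter) on this estimate. For compound 4 the estimated value is 200 nM with an expected range of 70 nM to 600 nM in this test.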

Compound 4, half-maximal inhibitory concentration: 180 nM
The estimate for compound 4 lay 1.1-fold (0.05 log units) above the measured number, and the stated range covers the measured number.
By their numbers in this assay, from the lowest: compounds 4, 2, 3 and 1 (each within the scatter of the next).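

In this assay, 3-methoxyphenyl in place of 2-methoxyphenyl gives a 1.1-fold lower number from compound 3 to compound 4 (0.02 log units; within the scatter) and shows that joining the same atoms differently at this position leaves the number within the scatter. The new group also sits within the scatter of the other two aromatic groups, with a 1.1-fold lower number from compound 2 to compound 4 (0.02 log units; within the scatter) and a 1.6-fold lower number from compound 1 to compound 4 (0.21 log units; within the scatter) as its steps, so all four compounds form one level group. No measurement shown explains this flat picture.

Still open, on these data alone, is whether an amine or a carboxylic acid on this aromatic group would stay level with these four compounds. The same question holds for a longer chain in place of methoxy.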